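Working notes: cyclobutyl on the sulfonamide nitrogen

The source may hold more compounds than are shown below. What is called first, only, known or untested is meant among the compounds shown, and "the series" means these compounds.

Measured in a physicochemical assay for lipophilicity, at pH 7.4; on this read-out higher numbers stand for higher lipophilicity and lower numbers for lower lipophilicity:
- compound 1 `CCc1ccc(N(CC2CCC2)S(=O)(=O)c2ccc3c(c2)C(=O)CC(C2CCOCC2)O3)cc1`: 4.1
- compound 2 `Cc1ccc(N(C2CCC2)S(=O)(=O)c2ccc3c(c2)C(=O)CC(C2CCOCC2)O3)c(C)c1`: 3.86
- compound 3 `CCc1ccc(NS(=O)(=O)c2ccc3c(c2)C(=O)CC(C2CCOCC2)O3)cc1`: 2.67

Compound 3 has the lowest number of the three, and the values of both other compounds stand beyond the scatter above it. The next step leads to compound 4 `CCc1ccc(N(C2CCC2)S(=O)(=O)c2ccc3c(c2)C(=O)CC(C2CCOCC2)O3)cc1`, not yet measured, and puts cyclobutyl in place of hydrogen on a sulfonamide nitrogen.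

For the measured compounds named here, one measured step bears directly on this change: a number 1.43 log units lower from compound 1 to compound 3 (beyond the scatter). It is large and beyond the scatter, with hydrogen in place of cyclobutylmethyl on a sulfonamide nitrogen. Read in reverse, it points to a large rise in this assay, although the group entering here is cyclobutyl and not cyclobutylmethyl. Compound 2 gives a second reference at 3.86, since it also carries cyclobutyl on a sulfonamide nitrogen, but it differs from compound 4 elsewhere in the structure. With only these compounds to go on, a large upward step is expected, close in size to the measured one or slightly smaller. The expected step is a number 1.18 log units higher from compound 3 to compound 4 (beyond the scatter). For compound 4 the estimated value is 3.85, with an expected range of 3.5 to 4.2.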

Compound 4, distribution coefficient: 3.78
Beside the measured number, compound 4's estimate is 0.07 log units above it, within the range that was stated.
By their numbers in this assay, from the lowest: compound 3; then compounds 4, 2 and 1 (each within the scatter of the next, the first and the last beyond it).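

In this assay, the effect of cyclobutyl in place of hydrogen on this sulfonamide nitrogen now has a direct reading, a number 1.11 log units higher from compound 3 to compound 4 (beyond the scatter), and cyclobutyl in place of cyclobutylmethyl gives a number 0.32 log units lower from compound 1 to compound 4 (beyond the scatter), so the two groups are separated by a modest step beyond the scatter. With cyclobutyl held on the nitrogen, 4-ethylphenyl in place of 2,4-dimethylphenyl gives a number 0.08 log units lower from compound 2 to compound 4 (within the scatter), so this exchange does not separate the two compounds in this assay. Nothing at hand accounts for the size of any of these steps.

As far as these compounds go, with only hydrogen, cyclobutyl and cyclobutylmethyl to compare on this nitrogen in the 4-ethylphenyl compounds, it remains open how an open-chain group such as isopropyl, or a longer chain ending in an amine or a carboxylic acid, would stand in this assay. Also open, from the compounds shown here alone, is whether the large step from hydrogen to cyclobutyl keeps its size when 2,4-dimethylphenyl takes the place of 4-ethylphenyl.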